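Aryl variation and tolerated concentration in this series

The compounds below may be only part of what the source reports. "The series", "measured", "known", "first", "only" and "open" are said of these compounds alone.

Compound 1 `COc1nc(C(C)(C)C)ccc1[C@@H](c1ccccc1)[C@@](O)(CCN(C)C)c1cccc2ccccc12` carries a tert-butyl group on the shared core. In a toxicity assay on HeLa cells (Homo sapiens) for cytotoxicity (a lower number here means that less compound is tolerated, a higher number that more compound is tolerated), compound 1 reaches only a limit of the assay, > 64 ug/mL. Compound 2 `COc1nc(-c2ccncc2)ccc1[C@@H](c1ccccc1)[C@@](O)(CCN(C)C)c1cccc2ccccc12` has pyridin-4-yl in its place, and in this assay compound 2 gives 9.6 ug/mL; the change is an at least 6.6-fold lower number from compound 1 to compound 2 (0.82 log units; beyond the scatter). Compound 3 `COc1nc(-c2ccc(F)cc2)ccc1[C@@H](c1ccccc1)[C@@](O)(CCN(C)C)c1cccc2ccccc12` carries 4-fluorophenyl; in this assay compound 3 again reaches only a limit, > 64 ug/mL. The step of an at least 6.6-fold higher number from compound 2 to compound 3 (0.82 log units; beyond the scatter) is beyond the scatter, while a step that the two limits leave unreadable from compound 1 to compound 3 cannot be read because the limit of > 64 ug/mL in this assay, at which 2 of the 3 values shown sit, is where both values sit. Compound 3 therefore stands at the upper edge of the numbers shown, alongside compound 1.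

Compound 4 `COc1nc(-c2ccc(Cl)c(F)c2)ccc1[C@@H](c1ccccc1)[C@@](O)(CCN(C)C)c1cccc2ccccc12` differs from compound 3 by 4-chloro-3-fluorophenyl in place of 4-fluorophenyl on an aromatic carbon. Within the data shown here, no measured step swaps one phenyl-type group for another; the only aryl-to-aryl step, an at least 6.6-fold higher number from compound 2 to compound 3 (0.82 log units; beyond the scatter), moved from a numbered value up to the limit, and the tert-butyl steps give no reading between two limits. For compound 4 the expectation is a number no higher from compound 3 to compound 4 (the limit leaves the size open), no step beyond the scatter. Compound 4 is estimated at 64 ug/mL, within 32 ug/mL to 128 ug/mL, most likely again reported only as a limit.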

Compound 4, half-maximal cytotoxic concentration: > 64 ug/mL
Compound 4 gave a limit, no number; the forecaster's own chance of this, stated with the estimate: 70%; the middle value sits exactly at the limit.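

A second halogenated phenyl group on this aromatic carbon next to the ring nitrogen gives the same kind of reading: in this assay compound 4 gives > 64 ug/mL, which is a limit and not a number. The step from the pyridin-4-yl group now repeats with a different phenyl group, an at least 6.6-fold higher number from compound 2 to compound 4 (0.82 log units; beyond the scatter), so among the compounds shown only the pyridin-4-yl group gives a numbered value. The steps among compound 1, compound 3 and compound 4 cannot be read because both values in each pair sit at the same limit: the limit of > 64 ug/mL in this assay, at which 3 of the 4 values shown sit.

As far as these compounds go, what the added chlorine does in this assay stays open, as the limit hides any difference. Also open, from the compounds shown here alone, is whether the lower number of compound 2 is tied to the pyridin-4-yl group alone; a pyridin-3-yl group or a phenyl group bearing an amine at this position would bear on that.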